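Halogen swap at the anilino ring: fluoro to chloro

A few compounds are considered here, and "the series" means these few. Any claim that something is new, unique, unknown or untested is made for them only; others in the source may bear on it.

For the measured compounds named here, compound 3 `COc1ccc(C(=O)c2sc(Nc3ccc(F)cc3)c(C(=O)O)c2C)cc1` gives 3.58% in a functional assay, with a stated time of 150 min, tested at 20 ug/mL (a higher number here means a stronger effect of the compound at the concentration tested, a lower number a weaker effect), the lowest of the two numbers so far; its nearest neighbour is compound 2 `COc1ccc(Nc2sc(C(=O)c3ccc(OC)cc3)c(C)c2C(=O)O)cc1` with 32.5%, and compound 1 `COc1ccc(C(=O)c2sc(Nc3ccc(C)cc3)c(C(=O)O)c2C)cc1` is reported as "not active" (no number reported) without a number. Compound 4 `COc1ccc(C(=O)c2sc(Nc3ccc(Cl)cc3)c(C(=O)O)c2C)cc1` differs from compound 3 by chloro in place of fluoro on an aromatic carbon. Going by the values given here, the only step recorded, a number 28.9 percentage points lower from compound 2 to compound 3 (beyond the scatter), concerns a different exchange, fluoro for methoxy, and no step for chloro replacing fluoro exists. A halogen-for-halogen change at the same aromatic carbon is therefore expected to leave this assay nearly unchanged, with a number 4.4 percentage points higher from compound 3 to compound 4 (within the scatter) expected to stay within the scatter. Compound 4 is estimated at 8%, within 0% to 25%.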

Compound 4, a percentage reported as activity, at one concentration (the size of the read-out at that concentration, not a potency): "not active" (no number reported)
Compound 4 has no reported number here; there is nothing to compare the estimate with.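

In this assay, for the compounds shown here, compound 4 gives "not active" (no number reported) and so no step from compound 3 can be read. No evidence bears on this result. The compounds shown leave open how chloro compares with fluoro at this place.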